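This account rests on a few compounds, and the source may have more. Where it says the series, first, only, none or still open, it means among the compounds named here.

In a functional assay on A549 cells (Homo sapiens) for antiproliferative activity, read by MTT assay (a higher number here means a weaker inhibitor, a lower number a stronger inhibitor), compound 3 `COc1ccc(/C=N/Nc2ncc3c(n2)n(C2CCCC2)c(=O)c(=O)n3C)cc1` gives > 100000 nM, which is a limit of the assay and not a number. Compound 1 `Cn1c(=O)c(=O)n(C2CCCC2)c2nc(N/N=C/c3ccccc3)ncc21` gives > 100000 nM, also a limit. Compound 2 `COc1ccc(/C=N/Nc2ncc3c(n2)n(C2CCCC2)c(=O)c(=O)n3C)c(OC)c1` gives > 100000 nM, again a limit. The three compounds therefore share one position: the limit of > 100000 nM in this assay, at which 3 of the 3 values shown sit.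

Compound 4 `Cn1c(=O)c(=O)n(C2CCCC2)c2nc(N/N=C/c3ccc(O)c(Br)c3)ncc21` has not yet been measured. It carries 3-bromo-4-hydroxyphenyl in place of 4-methoxyphenyl on a carbon with a double bond to nitrogen.

Within the data shown here, three measured steps touch this same group, and none of them has a readable size. They are a step that the two limits leave unreadable from compound 1 to compound 3, a step that the two limits leave unreadable from compound 1 to compound 2 and a step that the two limits leave unreadable from compound 2 to compound 3. Among the measured compounds shown here, no measured compound carries bromine or a hydroxy group, so the series offers no direct precedent for this change. The expectation of weak activity rests on compound 3, whose limit is > 100000 nM. Compound 4 may well be reported only as a limit too, and any number it does give is expected to lie towards the stronger side. The expected change is an at least 1.4-fold lower number from compound 3 to compound 4 (0.15 log units; that floor lies within the scatter), and its size is highly uncertain. Compound 4 is estimated at 70000 nM, with an expected range from 15000 nM to 150000 nM.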

Compound 4, half-maximal inhibitory concentration: 12800 nM
Beside the measured number, compound 4's estimate is 5.5-fold (0.74 log units) above it; the whole stated range lies above it.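

In this assay, among these compounds, the group on the carbon with a double bond to nitrogen proves able to bring activity into the measurable range, which the earlier compounds could not show: the change to 3-bromo-4-hydroxyphenyl gives an at least 7.8-fold lower number from compound 3 to compound 4 (0.89 log units; beyond the scatter), an at least 7.8-fold lower number from compound 2 to compound 4 (0.89 log units; beyond the scatter) and an at least 7.8-fold lower number from compound 1 to compound 4 (0.89 log units; beyond the scatter). Each of these sizes is only a floor, and the steps among compound 1, compound 2 and compound 3 cannot be read, so phenyl, 4-methoxyphenyl and 2,4-dimethoxyphenyl remain unranked against one another. Compound 4 alone stands apart from the shared limit: the limit of > 100000 nM in this assay, at which 3 of the 4 values shown sit.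

The change brings in bromine and a hydroxy group together, so the compounds shown leave open whether either one alone on the phenyl ring would give a measurable value or whether the step needs both. They also leave open whether chlorine in place of the bromine, or an amine in place of the hydroxy group, would keep the activity on the shared core.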